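Dropping the Methyl from a Pyrazine Hydrazide

The source may report more compounds than this note shows. Statements on the series, on what has been measured and on what is new or still open speak of the compounds shown alone.

Three related compounds have been tested in an ADME assay on THP-1 cells (Homo sapiens) for cytotoxicity, read by MTT assay, with a stated time of 5 days; a higher number here means a weaker inhibitor, a lower number a stronger inhibitor. For the measured compounds named here, compound 1, with the structure `CCOc1cc([C@H]2SCC(=O)N2NC(=O)c2nccnc2N)ccc1O`, is the only one to give a number: in this assay compound 1 gives 68.9 ug/mL. Compound 2, with the structure `Cc1cnc(C(=O)NN2C(=O)CS[C@@H]2c2ccc([N+](=O)[O-])cc2)cn1`, runs into the limit of the assay, and in this assay compound 2 gives > 100 ug/mL, a limit rather than a number. Compound 3, with the structure `Cc1cnc(C(=O)NN2C(=O)CS[C@H]2c2ccc(N(C)C)cc2)cn1`, also reaches that limit; in this assay compound 3 gives > 100 ug/mL, again a limit and not a number. Compound 2 therefore stands at the top of what the assay can read, alongside compound 3, and the picture is set by the limit of > 100 ug/mL in this assay, at which 2 of the 3 values shown sit.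

Compound 4, with the structure `O=C(NN1C(=O)CS[C@@H]1c1ccc([N+](=O)[O-])cc1)c1cnccn1`, has not yet been tested. It differs from compound 2 in one place: hydrogen in place of methyl on an aromatic carbon. Going by the values given here, no step between two measured compounds follows this particular change, so there is no measured guide to its size. Removing so small a piece is expected to leave the reading in this assay about where compound 2 sits, with no step beyond the usual scatter. Compound 4 is expected to give about 130 ug/mL, between 60 ug/mL and 300 ug/mL, and most likely to be reported only as a limit once more. The step is expected to be a step that the limit leaves unreadable from compound 2 to compound 4.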

Compound 4, half-maximal inhibitory concentration: 97.7 ug/mL
For compound 4 the middle estimate is 1.3-fold (0.12 log units) above the measured one; measured number inside the range.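

For the compounds shown here, compound 2 and compound 4 give the first measured step for this change, on an aromatic carbon of the six-membered ring with two nitrogens: in this assay, going from 5-methylpyrazin-2-yl to pyrazin-2-yl gives an at least 1.0-fold lower number from compound 2 to compound 4 (0.01 log units; that floor lies within the scatter). Compound 4 gives 97.7 ug/mL, an actual number rather than a limit, so without the methyl this compound can be read within the range of the assay. The step is only a floor and its true size stays unknown, because the value for compound 2 is a limit and the step can start only from there: the limit of > 100 ug/mL in this assay, at which 2 of the 4 values shown sit.

The compounds shown leave open whether taking the methyl off compound 3, with its dimethylamino group in place of the nitro group, would also give a number that can be read. They also leave open how a larger group at the same carbon, such as an ethyl or a methoxy group, would read in this assay.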